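This account rests on a few compounds, and the source may have more. Where it says the series, first, only, none or still open, it means among the compounds named here.

Measured in an ADME assay on L6 cells (Rattus norvegicus) for cytotoxicity, read by resazurin assay, with a stated time of 72 h; on this read-out lower numbers stand for stronger inhibition and higher numbers for weaker inhibition:
compound 1 `CC(C)(C)c1ccc(C(=O)NC(=O)c2ccccc2O)cc1` — 2.3 ug/mL
compound 2 `O=C(NC(=O)c1ccccc1O)c1ccc(-c2ccccc2)cc1` — a limit only, > 100 ug/mL

Compound 2 sits at the limit of this assay the limit of > 100 ug/mL in this assay, at which 1 of the 2 values shown sits, and shows the weakest inhibition of the two. Among the measured compounds shown here, the one measured step, an at least 43-fold higher number from compound 1 to compound 2 (1.63 log units; beyond the scatter), is large and runs toward weaker inhibition. Compound 3 `CN(C)c1ccc(C(=O)NC(=O)c2ccccc2O)cc1` differs from compound 2 by dimethylamino in place of phenyl on an aromatic carbon. For the measured compounds named here, no measured step touches dimethylamino; with the phenyl leaving, part of the loss seen in an at least 43-fold higher number from compound 1 to compound 2 (1.63 log units; beyond the scatter) is expected to be recovered, though the magnitude is uncertain. A step of an at least 4.0-fold lower number from compound 2 to compound 3 (0.60 log units; beyond the scatter) toward a lower number is expected. For compound 3 the estimate is 25 ug/mL, between 5 ug/mL and 100 ug/mL.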

Compound 3, half-maximal inhibitory concentration: 54 ug/mL
Compound 3: middle estimate off by 2.2-fold (0.33 log units), on the low side; the range from low to high includes it.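

In this assay, dimethylamino in place of tert-butyl on this aromatic carbon gives a 23-fold higher number from compound 1 to compound 3 (1.37 log units; beyond the scatter) and so the large move toward weaker inhibition does not require a phenyl or any ring at this position. Dimethylamino in place of phenyl gives an at least 1.8-fold lower number from compound 2 to compound 3 (0.26 log units; that floor lies within the scatter) and this floor does not separate the two groups. The value of compound 2 is a limit: the limit of > 100 ug/mL in this assay, at which 1 of the 3 values shown sits.

Open, from the compounds shown here alone, is whether tert-butyl is unusual at this position or whether other groups match it. An isopropyl, a cyclopropyl or a chlorine here would test this.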